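This account rests on a few compounds, and the source may have more. Where it says the series, first, only, none or still open, it means among the compounds named here.

Measured so far in this study:

Compound 1, `C=C1CC[C@H]2[C@@](C)(CCC(=O)[C@@]2(C)COC(C)=O)[C@@H]1C/C=C1/C(=O)OC[C@H]1Oc1c(Cl)cc(Cl)c2cccnc12`: > 100000 nM
Compound 2, `C=C1CC[C@H]2[C@@](C)(CCC(=O)[C@@]2(C)COC(C)=O)[C@@H]1C/C=C1/C(=O)OC[C@@H]1Oc1cccc2ccc(C)nc12`: 51700 nM

Among the measured compounds shown here, in an ADME assay on SNB-19 cells (Homo sapiens) for cytotoxicity, read by MTT assay, with a stated time of 24 h (a lower number here means that less compound is tolerated, a higher number that more compound is tolerated), compound 2 gives 51700 nM, which is the only actual number among the two values shown. Compound 1 gives > 100000 nM; this is a limit of the assay and not a number (the limit of > 100000 nM in this assay, at which 1 of the 2 values shown sits). Compound 3, `C=C1CC[C@H]2[C@@](C)(CCC(=O)[C@@]2(C)COC(C)=O)[C@@H]1C/C=C1/C(=O)OC[C@H]1Oc1cccc2ccc(C)nc12`, has not yet been measured. (the two compounds have the same atoms and bonds and differ only in configuration as drawn: 1 of 6 stereo elements differ; a stereocentre at a saturated ring carbon is drawn R in compound 2 and S in compound 3); in other words, the two compounds have the same atoms and bonds and differ only in configuration as drawn, at one stereocentre on a saturated ring carbon. For the measured compounds named here, no step between two measured compounds isolates such a change, so the expectation for compound 3 rests on the value of compound 2 alone. A single change of configuration at one ring carbon is expected to shift the half-maximal cytotoxic concentration by no more than the usual scatter, in either direction, so the step of a 1.2-fold higher number from compound 2 to compound 3 (0.06 log units; within the scatter) is expected to be small. Compound 3 is therefore estimated at 60000 nM, within a range from 25000 nM to 150000 nM.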

Compound 3, half-maximal cytotoxic concentration: > 100000 nM
Compound 3: only a limit was reported; the forecaster's own chance of this, stated with the estimate: 35%; at least 1.6-fold (0.22 log units) between middle value and limit.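

In this assay, changing only the configuration at one saturated ring carbon gives an at least 1.9-fold higher number from compound 2 to compound 3 (0.28 log units; that floor lies within the scatter). From the compounds shown here alone, compound 3 sits at a limit of the assay and not at a number, so the true size of this step is unknown, and the data do not establish a difference beyond the usual scatter. Even so, this is the first pair to isolate the configuration at this carbon, with nothing else altered: the fact that compounds 2 and 3 differ only in the configuration as drawn.

The step between compound 1 and compound 3 cannot be read, as both values are limits. Going by these compounds, it remains open how far compound 3 lies past its limit, and whether this change of configuration would have a similar effect with 5,7-dichloroquinolin-8-yl or with an amine on the same oxygen-linked quinoline group.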